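A few compounds are considered here, and "the series" means these few. Any claim that something is new, unique, unknown or untested is made for them only; others in the source may bear on it.

Measured in an ADME assay on the whole organism for metabolic stability, with Rattus norvegicus as the target; a lower number here means that the compound disappears faster, a higher number that the compound lasts longer:
- compound 1 `CSCC[C@H](NC(=O)c1ccc(CN(CC2CCCCC2)c2cccnc2)cc1-c1ccccc1C)C(=O)O`: < 0.4 h
- compound 2 `CSCC[C@H](NC(=O)c1ccc(CN(Cc2cc(F)cc(F)c2)c2cccnc2)cc1-c1ccccc1C)C(=O)O`: 1 h

The entry for compound 1 is a limit of the assay, not a number. Within the data shown here, compound 2 therefore holds the only actual number in this small set, 1 h, and the pair gives no wider range to place it in.

Compound 3 `CSCC[C@H](NC(=O)c1ccc(CN(Cc2cc(F)cc(F)c2)Cc2cncs2)cc1-c1ccccc1C)C(=O)O` differs from compound 2 by (1,3-thiazol-5-yl)methyl in place of pyridin-3-yl on an amine nitrogen. Among the measured compounds shown here, no measured step covers this exchange. For the measured compounds named here, the one step available, an at least 2.5-fold higher number from compound 1 to compound 2 (0.39 log units; beyond the scatter), put 3,5-difluorophenyl in place of cyclohexyl on a saturated chain carbon and left the pyridin-3-yl untouched. It therefore bears on the new change only indirectly. It does show that this assay can respond to a change on a group carried by this nitrogen, but it gives no direction for the present exchange.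

No step beyond the scatter is expected, and the estimated step is a 1.3-fold lower number from compound 2 to compound 3 (0.10 log units; within the scatter). In this assay compound 3 is estimated at 0.8 h, with an expected range from 0.3 h to 2 h.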

Compound 3, half-life: 1.13 h
Compound 3: middle estimate off by 1.4-fold (0.15 log units), on the low side; measured number inside the range.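

Among these compounds, exchanging pyridin-3-yl for (1,3-thiazol-5-yl)methyl on the amine nitrogen gives a 1.1-fold higher number from compound 2 to compound 3 (0.05 log units; within the scatter) in this assay, the first direct reading on this group of the series. Compound 2 and compound 3 cannot be told apart here, even though a six-membered aromatic ring with 1 hetero atom gives way to a five-membered aromatic ring with 2 hetero atoms, and the nitrogen now has a saturated chain carbon in that place, so for this one pair the read-out does not separate the two groups. Compound 1 alone carries a limit and not a number, so the exchange at this position rests on two actual numbers, and compound 1 is not part of that comparison: the limit of < 0.4 h in this assay, at which 1 of the 3 values shown sits.

The compounds shown leave open whether the same exchange would read alike with cyclohexyl in place of 3,5-difluorophenyl, as each change is seen on a single partner group. Also open, from the compounds shown here alone, is how a morpholine or a longer chain on this amine nitrogen would read in this assay, as one pair gives no trend for the position.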